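A few compounds are considered here, and "the series" means these few. Any claim that something is new, unique, unknown or untested is made for them only; others in the source may bear on it.

Of the compounds shown here, two sharing one core have been measured so far. In a functional assay on HL-60 cells (Homo sapiens) for antiproliferative activity, read by MTT assay, with a stated time of 72 h (a higher number here means that more compound is tolerated, a lower number that less compound is tolerated), compound 1 (`C/C1=C/CC[C@@]2(C)O[C@@H]2[C@H]2OC(=O)[C@@H](CN3CCCCC3)[C@@H]2CC1`) gives 10100 nM and compound 2 (`C/C1=C/CC[C@@]2(C)O[C@@H]2[C@H]2OC(=O)[C@@H](CN3CCC(F)CC3)[C@@H]2CC1`) gives 8070 nM, so compound 2 stands level with compound 1 within the scatter. The next structure is compound 3 (`C/C1=C/CC[C@@]2(C)O[C@@H]2[C@H]2OC(=O)[C@@H](CN3CCC(C(F)(F)F)CC3)[C@@H]2CC1`), which carries trifluoromethyl in place of fluoro on a saturated ring carbon. Going by the values given here, only one measured step bears on this change. It put fluoro in place of hydrogen on a saturated ring carbon, and it came to a 1.3-fold lower number from compound 1 to compound 2 (0.10 log units; within the scatter), which lies within the scatter. Among the compounds with values here, no measured compound carries trifluoromethyl yet, and a single small step shows no trend, so no shift beyond the scatter is expected in this assay. The estimated step is a 1.0-fold lower number from compound 2 to compound 3 (0.00 log units; within the scatter), with no clear direction. For compound 3 the estimated value is 8000 nM, with an expected range from 3800 nM to 16000 nM.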

Compound 3, concentration lethal to 50% of the cells: 3110 nM
For compound 3 the middle estimate is 2.6-fold (0.41 log units) above the measured one; the whole stated range lies above it.
By their numbers in this assay, from the lowest: compound 3; then compounds 2 and 1 (each within the scatter of the next).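

The substituent at this ring carbon, three ring bonds from the ring nitrogen, can shift the number beyond the scatter: in this assay the change from fluoro to trifluoromethyl gives a 2.6-fold lower number from compound 2 to compound 3 (0.41 log units; beyond the scatter) and so does more than the earlier fluoro for hydrogen step. Measured against the unsubstituted ring, trifluoromethyl gives a 3.2-fold lower number from compound 1 to compound 3 (0.51 log units; beyond the scatter) and compound 3 thus has the lowest number of the series, beyond the scatter of both other compounds. Nothing available explains this shift.

The compounds shown do not separate the effect of the fluorine atoms from that of a group with more heavy atoms, which a methyl or tert-butyl group on the same ring carbon could help to do. Going by these compounds, how a hydroxyl group or an amine would behave at this position also remains open.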